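The source may hold more compounds than are shown below. What is called first, only, known or untested is meant among the compounds shown, and "the series" means these compounds.

Compound 1 `Cn1c(=O)c2[nH]c(-c3ccc(OCCCCl)cc3)nc2n(C)c1=O` is the starting point of this short walk. In an assay on CHO cells for displacement of a labelled ligand from adenosine receptor A3 (Homo sapiens), read by scintillation counting, with a stated time of 3 h (on this read-out lower numbers stand for stronger inhibition and higher numbers for weaker inhibition), compound 1 gives > 30 nM, which is a limit of the measurement rather than a number. Compound 2 `Cn1c(=O)c2[nH]c(Cc3ccc(OCCCN4CCC5(CC4)OCCO5)cc3)nc2n(C)c1=O` belongs to the same series. In this assay compound 2 also gives > 30 nM, again a limit and not a number. Compound 1 therefore cannot be placed above or below anything: every value shown for it is a limit, and the whole of the evidence is the limit of > 30 nM in this assay, at which 2 of the 2 values shown sit. Among the measured compounds shown here, no two measured compounds differ in just one place, so no measured step exists to lean on.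

Compound 3 `Cn1c(=O)c2[nH]c(-c3ccc(OCCCn4ccnc4)cc3)nc2n(C)c1=O` is the compound still to be measured. Compared with compound 1 it shows (1H-imidazol-1-yl in place of chloro on a saturated chain carbon, three bonds along the chain from an oxygen on an aromatic ring). Nothing measured speaks to this change, so any expectation rests on the two limits alone. The expected step is a step that the limit leaves unreadable from compound 1 to compound 3, a shift that may well stay within the usual scatter and whose direction the data cannot fix. Compound 3 is thus expected to give 200 nM in this assay, with a range from 30 nM to 2000 nM, and a real chance that the measurement once more returns only a limit.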

Compound 3, inhibition constant: 2.27 nM
Beside the measured number, compound 3's estimate is 88-fold (1.95 log units) above it, outside the stated range (below it).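

Putting 1H-imidazol-1-yl in place of chloro on this saturated chain carbon gives, in this assay, an at least 13-fold lower number from compound 1 to compound 3 (1.12 log units; beyond the scatter). Among the compounds shown here, a lower number here stands for stronger inhibition, so this single change at the end of the chain moves the result well beyond the usual scatter, something the earlier compounds could not show with no measured step between them. The size of the step is only a minimum and not an exact figure, since it starts from a limit rather than a number: the limit of > 30 nM in this assay, at which 2 of the 3 values shown sit.

With only this one pair, the compounds shown cannot tell whether the difference comes from the arrival of the 1H-imidazol-1-yl ring or from the loss of the chloro, and the true size of the step stays unknown. From the compounds shown here alone, it also stays open whether an open-chain amine such as dimethylamino, another five-membered aromatic ring such as pyrazol-1-yl, or a longer chain carrying the same 1H-imidazol-1-yl would give a similar result.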